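Amino for nitro on two chalcone cores

The source may report more compounds than this note shows. Statements on the series, on what has been measured and on what is new or still open speak of the compounds shown alone.

Compound 1 `COc1cccc(/C=C/C(=O)c2ccc(OC)c([N+](=O)[O-])c2)c1` sits at a limit of a functional assay on B16 cells (Mus musculus) for cytotoxicity, read by MTT assay, with a stated time of 3 days (on this read-out higher numbers stand for weaker inhibition and lower numbers for stronger inhibition), where compound 1 gives > 100000 nM. Compound 2 `COc1cccc(/C=C/C(=O)c2ccc(OC)c(N)c2)c1` gives 33000 nM in this assay. The step of an at least 3.0-fold lower number from compound 1 to compound 2 (0.48 log units; beyond the scatter) follows from amino in place of nitro on an aromatic carbon.

Compound 3 `COc1cc(C(=O)/C=C/c2ccc([N+](=O)[O-])cc2)cc(OC)c1OC` also shows only a limit, > 100000 nM in this assay; note (the limit of > 100000 nM in this assay, at which 2 of the 3 values shown sit). How the core of compound 3 differs from that of compound 1 is not broken down here.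

Compound 4 `COc1cc(C(=O)/C=C/c2ccc(N)cc2)cc(OC)c1OC` is not yet measured. It differs from compound 3 by amino in place of nitro on an aromatic carbon. This is the same kind of change as from compound 1 to compound 2, but the place differs: there the amino stands ortho to a methoxy group and meta to a large group, here para to a large group.

Beside an at least 3.0-fold lower number from compound 1 to compound 2 (0.48 log units; beyond the scatter), a step of about an at least 3.3-fold lower number from compound 3 to compound 4 (0.52 log units; beyond the scatter) is expected for compound 4, resting on compound 2 at 33000 nM. The expected value for compound 4 is 30000 nM, between 8000 nM and 100000 nM.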

Compound 4, half-maximal inhibitory concentration: 30000 nM
The estimate for compound 4 equals the measured number at the digits printed, within the range that was stated.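

Amino in place of nitro on an aromatic carbon gives an at least 3.3-fold lower number from compound 3 to compound 4 (0.52 log units; beyond the scatter) in this assay, the same direction as on the core of compound 1. Compound 3 gives > 100000 nM, which is a limit, so this step is a bound and not a measured size. The direction therefore carries over between these two cores, though the amino group stands in a different place on each, and the sizes of the two steps cannot be compared: the same change on two cores in this assay, an at least 3.0-fold lower number (0.48 log units; beyond the scatter) from compound 1 to compound 2 and an at least 3.3-fold lower number (0.52 log units; beyond the scatter) from compound 3 to compound 4; the limit leaves it open whether they differ.

Open, going by these compounds, is whether a dimethylamino group or an acetamide in place of the amino on the core of compound 4 would shift the number in this assay. Also open, on these data alone, is whether the change holds on any core beyond these two.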